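The source may hold more compounds than are shown below. What is called first, only, known or untested is meant among the compounds shown, and "the series" means these compounds.

Working notes on the series.

Compound 1 `C=C1CC[C@@H]2[C@](C)(COC(C)=O)[C@H](OC(C)=O)CC[C@@]2(C)[C@@H]1C/C=C1/C(=O)OC[C@H]1OC(C)=O` gives, in a functional assay on Lu1 cells (Homo sapiens) for cytotoxicity, read by sulforhodamine B assay (a higher number here means that more compound is needed for the effect, a lower number that less compound is needed), a value of 12.4 uM. Compound 2 `C=C1CC[C@@H]2[C@](C)(CO)[C@H](OC(C)=O)CC[C@@]2(C)[C@@H]1C/C=C1/C(=O)OC[C@H]1OC(C)=O` is made from it by the change (hydrogen in place of acetyl on an oxygen on a saturated carbon), and in this assay compound 2 gives 8.75 uM; the step is a 1.4-fold lower number from compound 1 to compound 2 (0.15 log units; within the scatter). Among the compounds with values here, compound 3 `C=C1CC[C@@H]2[C@](C)(CO[Si](c3ccccc3)(c3ccccc3)C(C)(C)C)[C@H](OC(C)=O)CC[C@@]2(C)[C@@H]1C/C=C1/C(=O)OC[C@H]1OC(C)=O` gives 52.9 uM in this assay, the highest of the three numbers so far; the difference between the core of compound 1 and the core of compound 3 is not broken down here, and of that pair one can say only what the two values show.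

Compound 4 `C=C1CC[C@@H]2[C@](C)(CO[Si](c3ccccc3)(c3ccccc3)C(C)(C)C)[C@H](O)CC[C@@]2(C)[C@@H]1C/C=C1/C(=O)OC[C@H]1OC(C)=O` is not yet measured. It differs from compound 3 by hydrogen in place of acetyl on an oxygen on a saturated carbon. Within the data shown here, this is the same kind of change as the one from compound 1 to compound 2, though not the same: in the earlier pair the oxygen sits on a saturated carbon whose other neighbour is a saturated chain carbon, whereas in the new pair the other neighbour is a saturated ring carbon. Among the measured compounds shown here, since the one measured example of this kind of change, from compound 1 to compound 2, stayed within the scatter, the expectation for compound 4 in this assay is a step of about the same small size, a 1.3-fold lower number from compound 3 to compound 4 (0.12 log units; within the scatter), resting on the value of compound 3 at 52.9 uM. Compound 4 is thus expected to give about 40 uM, with a range from 20 uM to 85 uM, and it is expected to remain the higher number alongside compound 3.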

Compound 4, concentration for half-maximal effect: 11.9 uM
Estimate against measurement, compound 4: 3.4-fold (0.53 log units) above; measured number outside the range, below it.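

Set side by side in this assay, the two cases of this change do not agree: the same change on two cores in this assay, a 1.4-fold lower number (0.15 log units; within the scatter) from compound 1 to compound 2 and a 4.4-fold lower number (0.65 log units; beyond the scatter) from compound 3 to compound 4, 3.1-fold (0.50 log units) apart, beyond the scatter of two such steps

The change of acetoxy to hydroxy gives a 4.4-fold lower number from compound 3 to compound 4 (0.65 log units; beyond the scatter), so the size of the step read from one pair in this series cannot simply be carried to another core. What this does not show is the source of the disagreement: the oxygen sits on a saturated carbon whose other neighbour is a saturated chain carbon in the earlier pair and a saturated ring carbon in the new one, so both the place of the change and the rest of the molecule differ, and with a single pair of each kind these two differences cannot be separated.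

The compounds shown leave open whether acetoxy to hydroxy at the saturated carbon on a saturated ring carbon would give a step of similar size on the core of compound 1, and whether the same change at the other oxygen would hold on the core of compound 3. Also open, on these data alone, is how an amine or a carboxylic acid in place of that hydroxy would read in this assay.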